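This account rests on a few compounds, and the source may have more. Where it says the series, first, only, none or still open, it means among the compounds named here.

Compound 1, with the structure `COC(=O)/C=C/c1cccc(N(Cc2ccc(/C=C/c3scnc3C)cc2)C(=O)C2CCCCC2)c1`, is the starting point here. Among the compounds with values here, in an assay on isolated protein with Bile acid receptor (Homo sapiens) as the target (on this read-out higher numbers stand for an effect only at larger amounts of compound and lower numbers for an effect already at smaller amounts), compound 1 gives 227 nM, the lowest of the three numbers measured so far, although only one of the other two lies clearly apart from it. Compound 2 `COC(=O)/C=C/c1cccc(N(Cc2ccc(/C=C/c3scnc3C)cc2)C(=O)C(C)C)c1` carries isopropyl in place of cyclohexyl on a carbonyl carbon and gives 228 nM; the step of a 1.0-fold higher number from compound 1 to compound 2 (0.00 log units; within the scatter) lies within the usual scatter, so the two values cannot be told apart. Compound 3 `COC(=O)/C=C/c1cccc(N(C(=O)C2CCCCC2)c2ccc3ccccc3c2)c1` gives 680 nM, a higher number than compound 1 beyond the scatter, but it differs from compound 1 in more than one place, so no single step can be read from that pair.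

Compound 4 `COC(=O)/C=C/c1cccc(N(Cc2ccc(/C=C/c3c(Cl)cccc3Cl)cc2)C(=O)C2CCCCC2)c1` has not been measured. It differs from compound 1 in one place: 2,6-dichlorophenyl in place of 4-methyl-1,3-thiazol-5-yl on a double-bonded chain carbon bound to a double-bonded chain carbon. Within the data shown here, none of the measured steps touches this part of the molecule; the only single-point step known concerns the carbonyl substituent and did not move the number. There is therefore no basis for expecting a step beyond the scatter in either direction, and the estimate stays close to compound 1 with a wide range. The expected step is a 1.1-fold higher number from compound 1 to compound 4 (0.04 log units; within the scatter). Compound 4 is estimated at 250 nM, between 80 nM and 800 nM.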

Compound 4, half-maximal effective concentration: 150 nM
Estimate against measurement, compound 4: 1.7-fold (0.22 log units) above; measured number inside the range.
By their numbers in this assay, from the lowest: compounds 4, 1 and 2 (each within the scatter of the next); then compound 3.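

Placing 2,6-dichlorophenyl in place of 4-methyl-1,3-thiazol-5-yl on a double-bonded chain carbon bound to a double-bonded chain carbon gives, in this assay, a 1.5-fold lower number from compound 1 to compound 4 (0.18 log units; within the scatter) and so leaves the two compounds indistinguishable. Within the data shown here, this is the first single change at this end of the molecule, and it shows that a five-membered aromatic ring with nitrogen and sulfur can give way to a slightly larger six-membered ring of carbon bearing two chlorines without a step beyond the scatter; the hydrogen-bond acceptors counted in the thiazole are therefore not required to keep the number at this level. Nothing measured here explains why the number holds across this change.

Still open, as far as these compounds go, is whether this position accepts anything much different, such as a plain phenyl, a ring carrying an amine, or a carboxylic acid, or whether one of these would move the number beyond the scatter. From the compounds shown here alone, it is equally open whether the isopropyl group on the carbonyl carbon would behave as it did in compound 2 when combined with 2,6-dichlorophenyl.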